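Removing the tert-butyl group from compound 1

The source may report more compounds than this note shows. Statements on the series, on what has been measured and on what is new or still open speak of the compounds shown alone.

compound 1 `COc1cccc(CNCCCNc2ccnc3cc(-c4ccc(C(C)(C)C)cc4)ccc23)c1O` — 237 10^-6 cm/s
compound 2 `COc1ccc(F)cc1CNCCCNc1ccnc2cc(Cc3ccc(F)cc3Cl)ccc12` — 23 10^-6 cm/s
compound 3 `CC(C)(C)c1ccc(-c2ccc3c(NCCCNCc4ccco4)ccnc3c2)cc1` — 237 10^-6 cm/s

In an ADME assay for permeability, using PAMPA, with a stated time of 30 min, at pH 7.4 (a higher number here means that the compound crosses the layer faster, a lower number that the compound crosses the layer more slowly), compound 1 gives 237 10^-6 cm/s, level with compound 3 at the digits shown and together the highest of the three numbers; compound 2 gives 23 10^-6 cm/s, the furthest away. Compound 4 `COc1cccc(CNCCCNc2ccnc3cc(-c4ccccc4)ccc23)c1O` differs from compound 1 in one place: hydrogen in place of tert-butyl on an aromatic carbon. For the measured compounds named here, the only measured step, no change at the digits printed from compound 1 to compound 3 (within the scatter), changes a different part of the molecule, so no measured step bears directly on this change. Without such a step, compound 4 is expected to stay close to compound 1 in this assay, and the expected step of a 1.3-fold lower number from compound 1 to compound 4 (0.12 log units; within the scatter) is estimated to lie within the scatter. Compound 4 is therefore estimated at 180 10^-6 cm/s, with a range from 90 10^-6 cm/s to 320 10^-6 cm/s.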

Compound 4, apparent permeability: 237 10^-6 cm/s
Compound 4: middle estimate off by 1.3-fold (0.12 log units), on the low side; low and high end bracket the measured number.
By their numbers in this assay, from the lowest: compound 2; then compounds 1, 3 and 4 (each within the scatter of the next).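

In this assay, for the compounds shown here, the first measured step at this position, hydrogen in place of tert-butyl on an aromatic carbon, gives no change at the digits printed from compound 1 to compound 4 (within the scatter) in apparent permeability. Thus the 4-(tert-butyl)phenyl to phenyl change, which removes 4 heavy atoms, leaves the read-out as level as the step at the other end of the molecule, no change at the digits printed from compound 1 to compound 3 (within the scatter) at the furan-2-yl change. No measurement shown here accounts for this result. As far as these compounds go, what an amine or a carboxylic acid on this aromatic carbon would give remains open, as does whether the phenyl result holds with furan-2-yl in the molecule.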